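The source may report more compounds than this note shows. Statements on the series, on what has been measured and on what is new or still open speak of the compounds shown alone.

Working notes on the series. For the measured compounds named here, in a functional assay on T47D cells (Homo sapiens) for cytotoxicity, read by CCK-8 assay, with a stated time of 4 days (a lower number here means a stronger inhibitor, a higher number a weaker inhibitor), compound 1 `Oc1ccc(-c2cc(-c3cccc(O)c3)nc(-c3cccc(O)c3)c2)cc1` gives 2230 nM, the second highest of the three numbers so far. Compound 3 `Oc1cccc(-c2cc(-c3cccc(O)c3)nc(-c3cccc(O)c3)c2)c1` sits nearest with 2050 nM, the step of a 1.1-fold lower number from compound 1 to compound 3 (0.04 log units; within the scatter) staying within the scatter. Compound 2 `Oc1cccc(-c2cc(-c3ccccc3O)cc(-c3cccc(O)c3)n2)c1` gives 4570 nM, the step of a 2.0-fold higher number from compound 1 to compound 2 (0.31 log units; beyond the scatter) being modest; likewise a 2.2-fold lower number from compound 2 to compound 3 (0.35 log units; beyond the scatter).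

Compound 4 `Oc1ccc(-c2cc(-c3ccc(O)cc3)nc(-c3cccc(O)c3)c2)cc1` differs from compound 1 by 4-hydroxyphenyl in place of 3-hydroxyphenyl on an aromatic carbon. Going by the values given here, the closest precedent is the swap of a 3-hydroxyphenyl for a 4-hydroxyphenyl between compound 1 and compound 3, which gave a 1.1-fold lower number from compound 1 to compound 3 (0.04 log units; within the scatter); only the move of the hydroxyl to the 2-position, as in compound 2, moved the number beyond the scatter. For this assay the step of a 1.0-fold higher number from compound 1 to compound 4 (0.01 log units; within the scatter) is therefore expected to stay within the scatter. Compound 4 is estimated at 2300 nM, range 1200 nM to 4500 nM.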

Compound 4, half-maximal inhibitory concentration: 4470 nM
Estimate against measurement, compound 4: 1.9-fold (0.29 log units) below; the range from low to high includes it.
By their numbers in this assay, from the lowest: compounds 3, 1, 4 and 2 (each within the scatter of the next, the first and the last beyond it).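

The hydroxyl position on the aryl group next to the ring nitrogen can also be moved without leaving the scatter in this assay, with a 2.0-fold higher number from compound 1 to compound 4 (0.30 log units; within the scatter). This step, at the carbon next to the ring nitrogen, lies at the upper end of what the scatter allows, and so is much larger than the 3-hydroxyphenyl swap at the other aryl group, a 1.1-fold lower number from compound 1 to compound 3 (0.04 log units; within the scatter), though both are printed as within the scatter.

The compounds shown leave open how a 2-hydroxyphenyl, a methoxyphenyl or an aminophenyl would read at this carbon. Nothing available bears on the reason for this result.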